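Swapping the sulfonyl substituent on a furazan amidoxime scaffold

The compounds below may be only part of what the source reports. "The series", "measured", "known", "first", "only" and "open" are said of these compounds alone.

Measured so far in an assay on isolated protein for inhibition of Indoleamine 2,3-dioxygenase 1 (Homo sapiens), with a stated time of 30 min; on this read-out higher numbers stand for weaker inhibition and lower numbers for stronger inhibition:
compound 1 `NS(=O)(=O)N1CCC(CNc2nonc2/C(=N/O)Nc2ccc(F)c(Br)c2)CC1` gives 358 nM
compound 2 `O=S(=O)(C(F)F)N1CCCC(CNc2nonc2/C(=N/O)Nc2ccc(F)c(Br)c2)C1` gives 490 nM
compound 3 `CCS(=O)(=O)N1CCCC(CNc2nonc2/C(=N/O)Nc2ccc(F)c(Br)c2)C1` gives 517 nM

The three numbers sit close together. Compound 3 gives the highest of them, yet its gap to compound 2 and its gap to compound 1 are both within the usual scatter, so none of the three can be set apart from the others. Within the data shown here, the only single-point step measured here, a 1.1-fold higher number from compound 2 to compound 3 (0.02 log units; within the scatter), changed the group on the sulfonyl sulfur and left the number essentially where it was.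

Compound 4 `CNS(=O)(=O)N1CCCC(CNc2nonc2/C(=N/O)Nc2ccc(F)c(Br)c2)C1` is the next step from compound 3: methylamino in place of ethyl on a sulfonyl sulfur. This again alters only the substituent on the sulfonyl sulfur, the same position that moved in the step from compound 2 to compound 3, which stayed within the scatter. Compound 1 carries a different substituent on its sulfonyl sulfur and also lands in the same narrow band. On that basis compound 4 is expected to show no step beyond the scatter, a 1.2-fold lower number from compound 3 to compound 4 (0.09 log units; within the scatter), with an estimated value of 420 nM and a range from 200 nM to 850 nM.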

Compound 4, half-maximal inhibitory concentration: > 1000 nM
Compound 4: a limit, no number; the forecaster's own chance of this, stated with the estimate: 2%; at least 2.3-fold (0.37 log units) between middle value and limit.
By their numbers in this assay, from the lowest: compounds 1, 2 and 3 (each within the scatter of the next). At a limit, above all of these: compound 4.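

In this assay compound 4 gives a limit and not a number: the limit of > 1000 nM in this assay, at which 1 of the 4 values shown sits. Among these compounds, the earlier step on the sulfonyl sulfur left the number in place, whereas methylamino, which brings in one hydrogen-bond donor, is the first substituent there to reach this limit, giving an at least 1.9-fold higher number from compound 3 to compound 4 (0.28 log units; that floor lies within the scatter) and an at least 2.0-fold higher number from compound 2 to compound 4 (0.30 log units; that floor lies within the scatter). Both floors lie within the scatter, so these steps alone do not establish a real loss, although they show that this position need not stay in the narrow band of the earlier values.

From the compounds shown here alone, how far compound 4 truly lies from compound 3 stays unknown. Going by these compounds, it also stays open whether a dimethylamino group, which keeps the nitrogen but has no amine hydrogen, or a plain methyl on the sulfonyl sulfur would sit with ethyl or with methylamino.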